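The source may hold more compounds than are shown below. What is called first, only, known or untested is meant among the compounds shown, and "the series" means these compounds.

Measured so far in an assay on cells for binding affinity to Cyclin-C/Cyclin-dependent kinase 19 (Homo sapiens), read by LanthaScreen; on this read-out higher numbers stand for weaker inhibition and lower numbers for stronger inhibition:
- compound 1 `Cn1ncc2cc(-c3cnc4[nH]ccc4c3N3CCC4(CCNC4=O)CC3)ccc21` gives 7 nM
- compound 2 `Cn1ncc2cc(-c3cnc4[nH]ncc4c3N3CCC4(CCNC4=O)CC3)ccc21` gives 214 nM
- compound 3 `Cn1ncc2cc(-c3cnc4[nH]cnc4c3N3CCC4(CCNC4=O)CC3)ccc21` gives 5 nM

Compound 1 sits second highest of the three numbers; its nearest neighbour is compound 3, within the scatter, and the gap to compound 2 lies beyond it. The shared core carries, ortho to a large group, the aryl substituent that varies here. Compound 4 `O=C1NCCC12CCN(c1c(-c3ccc4scnc4c3)cnc3[nH]ccc13)CC2` is not yet measured in this assay; it changes compound 1 by 1,3-benzothiazol-5-yl in place of 1-methyl-1H-indazol-5-yl on an aromatic carbon. Going by the values given here, no measured pair shows this exchange, and the aryl group retains its acceptor count while gaining sulfur for nitrogen. A small weakening, or none beyond the scatter, is expected from compound 1 to compound 4, a 2.1-fold higher number from compound 1 to compound 4 (0.33 log units; beyond the scatter). For compound 4 the estimate in this assay is 15 nM, with a range from 4 nM to 60 nM.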

Compound 4, half-maximal inhibitory concentration: 14 nM
Compound 4: the middle estimate sits 1.1-fold (0.03 log units) above what was measured, within the range that was stated.
By their numbers in this assay, from the lowest: compounds 3, 1 and 4 (each within the scatter of the next, the first and the last beyond it); then compound 2.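

Going by these compounds alone, compounds 1 to 3 all carry 1-methyl-1H-indazol-5-yl, so this is the first reading of a change at this aromatic carbon. In this assay, 1,3-benzothiazol-5-yl in place of 1-methyl-1H-indazol-5-yl gives a 2.0-fold higher number from compound 1 to compound 4 (0.30 log units; within the scatter), so the position accepts a second aryl group, with sulfur in its five-membered ring, without a change beyond the scatter. No measured evidence bears on this result.

Open, going by these compounds, is how a plain phenyl or a morpholine would read at this position. Also open, on these data alone, is whether the same exchange holds on the cores of compound 2 and compound 3.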